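Swapping an Unsaturated Ether Chain for a Saturated One

The source may report more compounds than this note shows. Statements on the series, on what has been measured and on what is new or still open speak of the compounds shown alone.

Measured in a functional assay on A2780/DX3 cells (Homo sapiens) for antiproliferative activity, read by MTT assay, with a stated time of 3 days; a higher number here means a weaker inhibitor, a lower number a stronger inhibitor:
Compound 1 `CC/C=C/COC1(c2ccc(Cl)cc2)SC=C(C)n2c1noc2=O` gives 88000 nM.
Compound 2 `CC1=CSC(O)(c2ccc([N+](=O)[O-])cc2)c2noc(=O)n21` gives only a limit of the assay, > 100000 nM.
Compound 3 `CC1=CSC(O)(c2cccc(C(F)(F)F)c2)c2noc(=O)n21` gives 71000 nM.

All three compounds share the same core and are weak inhibitors in this assay . Among the two compounds with a number, compound 1 stands highest, but compound 3 lies so close to it that the gap falls within the usual scatter of repeated measurements, so no order between compound 1 and compound 3 can be read from these values. Compound 2 reached only the limit of the assay , (the limit of > 100000 nM in this assay, at which 1 of the 3 values shown sits), and so contributes no number at all.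

The unmeasured compound 4 `CCCCOC1(c2ccc(Cl)cc2)SC=C(C)n2c1noc2=O` differs from compound 1 in one place: propyl in place of but-1-en-1-yl on a saturated chain carbon bound to an oxygen on a saturated carbon. The change is a small one, on the chain that sits on the oxygen rather than on the core itself, and it removes one carbon and the double bond. Within the data shown here, with no measured step of this kind to lean on, the expectation is that the step of a 1.0-fold higher number from compound 1 to compound 4 (0.01 log units; within the scatter) stays within the scatter, in no clear direction. On that basis compound 4 is estimated to give about 90000 nM in this assay , with a range from 40000 nM to 200000 nM.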

Compound 4, half-maximal inhibitory concentration: 49000 nM
Beside the measured number, compound 4's estimate is 1.8-fold (0.26 log units) above it; the measured number falls inside the stated range.
By their numbers in this assay, from the lowest: compounds 4, 3 and 1 (each within the scatter of the next). At a limit, above all of these: compound 2.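

Among these compounds, this is the first measured step at this position: in this assay, propyl in place of but-1-en-1-yl on a saturated chain carbon bound to an oxygen on a saturated carbon gives a 1.8-fold lower number from compound 1 to compound 4 (0.25 log units; within the scatter). The double bond outside the aromatic rings can therefore be lost, together with the change to the shorter chain, without a step beyond the scatter, so this pair gives no sign that the double bond matters for the activity read here. No measurement shown here offers any explanation for this result.

Still open, going by these compounds, is whether a much longer chain such as octyl, or a chain ending in an amine or a carboxylic acid, on this same oxygen would produce a step beyond the scatter. On these data alone, it is also open whether swapping but-1-en-1-yl for propyl would read the same way on a compound with a group other than chlorine on the aromatic ring, such as a methoxy group.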